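This account rests on a few compounds, and the source may have more. Where it says the series, first, only, none or still open, it means among the compounds named here.

Of the compounds shown here, three that share one core have so far been measured in an assay on isolated protein (Vas deferens, strain Sprague-Dawley) for antagonist activity at Alpha-1A adrenergic receptor (Rattus norvegicus), with a stated time of 20 min; on this read-out lower numbers stand for tighter binding and higher numbers for weaker binding. Compound 1 `COc1ccccc1N1CCN(CCCNC(=O)c2ccc3[nH]ccc3c2)CC1` gives 26.3 nM in this assay. Compound 2 `COc1ccccc1N1CCN(CCCNC(=O)Cc2c[nH]c3ccccc23)CC1` gives 7.94 nM, and compound 3 `COc1ccccc1N1CCN(CCCNC(=O)c2cc3cc(Cl)ccc3[nH]2)CC1` gives 47.9 nM. Among the compounds with values here, compound 3 thus carries the highest of the three numbers, although only one of its steps is clear-cut: the step of a 6.0-fold higher number from compound 2 to compound 3 (0.78 log units; beyond the scatter) lies beyond the scatter, whereas the step of a 1.8-fold higher number from compound 1 to compound 3 (0.26 log units; within the scatter) stays within it, so compound 1 and compound 3 cannot be told apart. Compound 4 `COc1ccccc1N1CCN(CCCNC(=O)c2cn(C)c3ccccc23)CC1` has not yet been measured. It differs from compound 3 in one place: 1-methyl-1H-indol-3-yl in place of 5-chloro-1H-indol-2-yl on a carbonyl carbon. Within the data shown here, two measured steps bear on this change. The step of a 3.3-fold lower number from compound 1 to compound 2 (0.52 log units; beyond the scatter) and the step of a 6.0-fold higher number from compound 2 to compound 3 (0.78 log units; beyond the scatter) both exchange the group on the carbonyl carbon and shift the number by a modest amount, while the step of a 1.8-fold higher number from compound 1 to compound 3 (0.26 log units; within the scatter) shows an exchange of that group that stays within the scatter. Among the measured compounds shown here, no measured pair removes the hydrogen-bond donor of the group in favour of a 1-methyl-1H-indol-3-yl group, so that part of the change is untested. Compound 4 is expected to give 20 nM in this assay, somewhere between 5 nM and 80 nM. That estimate means an expected step of a 2.4-fold lower number from compound 3 to compound 4 (0.38 log units; beyond the scatter), a modest lowering held with little confidence.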

Compound 4, dissociation constant: 52.5 nM
The estimate for compound 4 lay 2.6-fold (0.42 log units) below the measured number, and the stated range covers the measured number.
By their numbers in this assay, from the lowest: compound 2; then compounds 1, 3 and 4 (each within the scatter of the next).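

In this assay, the change on the carbonyl carbon gives a 1.1-fold higher number from compound 3 to compound 4 (0.04 log units; within the scatter) and so cannot be told from no change, even though the group goes from 1 hydrogen-bond donor to 0 hydrogen-bond donors and loses its chlorine; these two differences come together, so neither can be judged alone. The measurement a 2.0-fold higher number from compound 1 to compound 4 (0.30 log units; within the scatter) also stays within the scatter, so compounds 1, 3 and 4, whose indolyl groups sit directly on the carbonyl carbon, cannot be separated, whereas a 6.6-fold higher number from compound 2 to compound 4 (0.82 log units; beyond the scatter) sets compound 2 and its (1H-indol-3-yl)methyl group apart from compound 4 by more than the scatter. Nothing measured here explains why the three directly attached groups read alike or why compound 2 differs.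

The compounds shown leave open what the 1-methyl group contributes by itself, which a plain 1H-indol-3-yl group on the same carbonyl carbon would show, and what the chlorine contributes, which a plain 1H-indol-2-yl group would show. They also leave open whether a longer chain, such as 2-(1H-indol-3-yl)ethyl, would keep the number as low as that of compound 2.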